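The source may hold more compounds than are shown below. What is called first, only, known or untested is meant among the compounds shown, and "the series" means these compounds.

Working notes on a small set of anilines measured in a functional assay on MGC-803 cells (Homo sapiens) for inhibition, read by MTT assay, with a stated time of 48 h; on this read-out higher numbers stand for weaker inhibition and lower numbers for stronger inhibition.

Going by the values given here, compound 1 `CCCCC(=O)N(Cc1ccc(OC)c(O)c1)c1cc(OC)c(OC)c(OC)c1` stands lowest of the three numbers measured so far: in this assay compound 1 gives 66 nM. Compound 3 `COc1ccc(CNc2cc(OC)c(OC)c(OC)c2)cc1N` gives 7970 nM and compound 2 `COc1cc(NCc2cccc(O)c2)cc(OC)c1OC` gives 57600 nM. Among the compounds with values here, both of these differ from compound 1 in more than one place, so no single counted step connects them; taken only as numbers, compound 3 lies closest to compound 1 and compound 2 lies furthest from it, and both gaps are beyond the scatter.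

Compound 4 `COc1ccc(CN(C(=O)C2CC2)c2cc(OC)c(OC)c(OC)c2)cc1O` has not yet been measured. Relative to compound 1 it carries one change: cyclopropyl in place of butyl on a carbonyl carbon. The acyl group on the amide-type nitrogen is kept, so compound 4 stays on the side of the set where compound 1 sits, rather than with compound 2 or compound 3. Within the data shown here, no measured pair shows this butylcarbonyl to cyclopropylcarbonyl change, so its effect can only be guessed. The step of a 1.7-fold higher number from compound 1 to compound 4 (0.22 log units; within the scatter) is expected to be small, at most a modest weakening, and may well fall within the scatter. Compound 4 is thus estimated at 110 nM, with a plausible range from 30 nM to 450 nM in this assay, pending the measurement.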

Compound 4, half-maximal inhibitory concentration: 59 nM
The estimate for compound 4 lay 1.9-fold (0.27 log units) above the measured number, and the stated range covers the measured number.
By their numbers in this assay, from the lowest: compounds 4 and 1 (each within the scatter of the next); then compound 3; then compound 2.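

In this assay, going by these compounds alone, the step of a 1.1-fold lower number from compound 1 to compound 4 (0.05 log units; within the scatter) is the first single-place comparison, and it concerns a carbonyl carbon whose other neighbour is the amide-type nitrogen. At this place, butyl with 4 heavy atoms and no ring and cyclopropyl with 3 heavy atoms in a three-membered ring cannot be told apart on this read-out, so for this one pair neither the open chain nor the fourth carbon is needed for a number of this size. No evidence at hand bears on why the two groups read alike.

On these data alone, the two compounds say nothing about other groups on this carbonyl carbon, such as a longer chain, a phenyl ring or a chain carrying an amine, so how much change this place accepts beyond butyl and cyclopropyl remains open. As far as these compounds go, compound 2 and compound 3 carry no acyl group but also differ from compound 1 elsewhere, so the share of their large gaps that belongs to the acyl group itself also remains open.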